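Flipping One Ring Stereocentre in an Iminosugar Acid

This account rests on a few compounds, and the source may have more. Where it says the series, first, only, none or still open, it means among the compounds named here.

In an assay for inhibition of alpha-N-acetylgalactosaminidase (Gallus gallus), tested at 1000 uM (a lower number here means less inhibition, a higher number more inhibition at the concentration tested (going by the name of the read-out)), compound 1 `O=C(O)[C@H]1NC[C@H](O)[C@@H](O)[C@@H]1O` gives 0.2%, and compound 2 `O=C(O)[C@@H]1NC[C@H](O)[C@@H](O)[C@H]1O` gives 4%. Compound 2 has the higher of the two numbers, yet the step of a number 3.8 percentage points higher from compound 1 to compound 2 (within the scatter) lies within the usual scatter, so the two compounds cannot be told apart on these data. Compound 3 `O=C(O)[C@@H]1NC[C@H](O)[C@H](O)[C@H]1O` is the next candidate; the change from compound 2 is the two compounds have the same atoms and bonds and differ only in configuration as drawn: 1 of 4 stereo elements differ; a stereocentre at a saturated ring carbon is drawn R in compound 2 and S in compound 3. Among the compounds with values here, the only measured step that bears on this is the one from compound 1 to compound 2, where two stereocentres were changed at once and the read-out in this assay barely moved (the fact that compounds 1 and 2 differ only in the configuration as drawn). With a single stereocentre now changing, no step beyond the scatter is expected in this assay: the estimated step is no change at the digits printed from compound 2 to compound 3 (within the scatter). Compound 3 is therefore expected to give about 4% in this assay, within a range from 0% to 14%.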

Compound 3, a percentage reported as inhibition, at one concentration (the size of the read-out at that concentration, not a potency): 4.4%
Beside the measured number, compound 3's estimate is 0.4 percentage points below it; the measured number falls inside the stated range.
By their numbers in this assay, from the lowest: compounds 1, 2 and 3 (each within the scatter of the next).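

Taken alone, inverting this one stereocentre at a saturated ring carbon gives a number 0.4 percentage points higher from compound 2 to compound 3 (within the scatter) in this assay, the first measured case of a single configurational change in this set. Even when three of the four stereo elements differ, the result is a number 4.2 percentage points higher from compound 1 to compound 3 (within the scatter), so a larger configurational change also stays inside the scatter. These three stereoisomers therefore cannot be told apart in this assay, and the comparison isolates configuration alone: the fact that compounds 1 and 3 differ only in the configuration as drawn

On these data alone, whether single inversions at the other stereocentres would give a step beyond the scatter remains open. Also open, as far as these compounds go, is how this assay would respond if the carboxylic acid were replaced by a hydroxymethyl group or an amide, or if a longer chain were attached to the amine of the shared core.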